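A few compounds are considered here, and "the series" means these few. Any claim that something is new, unique, unknown or untested is made for them only; others in the source may bear on it.

Of the compounds shown here, two have so far been measured in a physicochemical assay for lipophilicity, at pH 7.4; on this read-out higher numbers stand for higher lipophilicity and lower numbers for lower lipophilicity. Compound 1 `COc1ccc(-c2c(C)nc3c(NCC4CCOCC4)cc(C)cn23)cc1OC` gives 6, and compound 2 `COc1ccc(-c2c(C)nn3c(NCc4ccc(C(N)=O)cc4)nc(C)cc23)cc1OC` gives 4.8. Compound 2 therefore stands lowest of the two numbers; its nearest neighbour is compound 1, whose number sits higher by a gap that lies beyond the usual scatter of repeated measurements of this kind. Going by the values given here, no measured pair differs in only one place, so no single step can be read off directly from the numbers in hand.

Compound 3 `COc1ccc(-c2c(C)nn3c(NCc4cccnc4)nc(C)cc23)cc1OC` has not yet been measured. It differs from compound 2 in one place: pyridin-3-yl in place of 4-carbamoylphenyl on a saturated chain carbon bound to a nitrogen on an aromatic ring. Among the compounds with values here, with no measured step of this sort to lean on, the expectation for this change can rest only on the swap itself and on where compound 2 stands. The expected step of a number 0.10 log units higher from compound 2 to compound 3 (within the scatter) is small, small enough to fall within the scatter, in whichever direction it finally points. The estimate for compound 3 in this assay is 4.9, with a range from 4.3 to 5.5.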

Compound 3, distribution coefficient: 5.5
The estimate for compound 3 lay 0.60 log units below the measured number, and the stated range covers the measured number.
By their numbers in this assay, from the lowest: compound 2; then compound 3; then compound 1.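

Going by these compounds alone, this is the first single-place change that can be read directly: in this assay the swap of 4-carbamoylphenyl for pyridin-3-yl gives a number 0.70 log units higher from compound 2 to compound 3 (beyond the scatter) and so shows that the group on this saturated chain carbon bound to a nitrogen on an aromatic ring can shift the read-out by a modest but real amount. Within the data shown here, the swap alters several things together, since the entering group has fewer heavy atoms than the leaving group, the hydrogen-bond donor of the leaving group has no counterpart in the entering one, and a ring of carbon only gives way to a ring with a hetero atom, and this single step cannot pull those changes apart. Nothing in hand accounts for the direction or size of the step.

A plain phenyl on the same carbon would help to separate the part played by the carbamoyl group from that of the ring nitrogen, while a carboxylic acid or an amine in place of the carbamoyl group would show how far other groups at this spot move the number. As far as these compounds go, whether the step would keep its size on a different core, such as that of compound 1, also remains open.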